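Swapping an Imidazole for a Pyridine Amide

The source may report more compounds than this note shows. Statements on the series, on what has been measured and on what is new or still open speak of the compounds shown alone.

Measured in an ADME assay on microsomes from liver (Homo sapiens) for metabolic stability, read by LC-MS, using NADPH, with stated times of 5 min and 30 min, tested at 1 uM; a higher number here means faster removal of the compound, a lower number slower removal:
compound 1 `Cc1nccn1-c1cnc(NCc2c(F)ccc3c2CCO3)c2cn[nH]c(=O)c12` gives 8 mL.min-1.g-1
compound 2 `CN(c1ccn(C)n1)c1cnc(NCc2c(F)ccc3c2CCO3)n2cnnc12` gives 11 mL.min-1.g-1

Compound 1 has the lowest of the two numbers, and compound 2 lies within the usual scatter of it, so the two cannot be told apart. Compound 3 `CNC(=O)c1ccc(-c2cnc(NCc3c(F)ccc4c3CCO4)c3cn[nH]c(=O)c23)c(C)n1` has not yet been measured in this assay. It differs from compound 1 in one place: 2-methyl-6-(methylcarbamoyl)pyridin-3-yl in place of 2-methyl-1H-imidazol-1-yl on an aromatic carbon. Among the measured compounds shown here, no step between measured compounds is available to guide this change. The number for compound 3 is expected to stay near that of compound 1, with a 1.5-fold higher number from compound 1 to compound 3 (0.18 log units; within the scatter) not beyond the scatter. Compound 3 is therefore estimated at 12 mL.min-1.g-1, between 5 mL.min-1.g-1 and 30 mL.min-1.g-1.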

Compound 3, intrinsic clearance in microsomes: 23 mL.min-1.g-1
Compound 3: the middle estimate sits 1.9-fold (0.28 log units) below what was measured, within the range that was stated.
By their numbers in this assay, from the lowest: compounds 1 and 2 (each within the scatter of the next); then compound 3.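

In this assay the swap of 2-methyl-1H-imidazol-1-yl for 2-methyl-6-(methylcarbamoyl)pyridin-3-yl gives a 2.9-fold higher number from compound 1 to compound 3 (0.46 log units; beyond the scatter) and so shows that this position on the shared core can change how fast the compound is removed. The larger group is the one removed faster here, though the step is modest. No measurement at hand explains why. The compounds shown leave open whether the pyridine ring or its methylcarbamoyl group accounts for the step. A 2-methylpyridin-3-yl group without the amide, or a carboxylic acid in its place, would help separate the two.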